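The compounds below may be only part of what the source reports. "The series", "measured", "known", "first", "only" and "open" are said of these compounds alone.

In a functional assay on A549 cells (Homo sapiens) for cytotoxicity, read by MTT assay, with a stated time of 72 h (a higher number here means a weaker inhibitor, a lower number a stronger inhibitor), compound 1 (`CC1=CCC[C@H]2[C@](C)(CC3=CC(=O)C=C(NCCC(=O)O)C3=O)[C@@H](C)CC[C@]12C`) gives 26900 nM and compound 2 (`CC1=CCC[C@H]2[C@](C)(CC3=CC(=O)C=C(NCC(=O)O)C3=O)[C@@H](C)CC[C@]12C`) gives 46700 nM, so these two numbers lie within the usual scatter of each other. Compound 3 (`CC1=CCC[C@H]2[C@](C)(CC3=CC(=O)C=C(N[C@@H](C(=O)O)C(C)C)C3=O)[C@@H](C)CC[C@]12C`) follows from compound 2 through isopropyl in place of hydrogen on a saturated chain carbon bound to an amine nitrogen and a carbonyl carbon. Among the measured compounds shown here, the only measured step, a 1.7-fold higher number from compound 1 to compound 2 (0.24 log units; within the scatter), concerns the same chain but a different change, so it is a weak guide, and no clear direction is expected. The expected outcome is a 1.2-fold lower number from compound 2 to compound 3 (0.07 log units; within the scatter), no shift beyond the scatter. In this assay the estimated value for compound 3 is 40000 nM, with an expected range of 15000 nM to 90000 nM.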

Compound 3, half-maximal inhibitory concentration: 23800 nM
Estimate against measurement, compound 3: 1.7-fold (0.23 log units) above; measured number inside the range.
By their numbers in this assay, from the lowest: compounds 3, 1 and 2 (each within the scatter of the next).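

In this assay, isopropyl in place of hydrogen on this saturated chain carbon gives a 2.0-fold lower number from compound 2 to compound 3 (0.29 log units; within the scatter), so this first substituent at that carbon leaves the number within the scatter. Replacing 2-carboxyethyl with 1-carboxy-2-methylpropyl on the amine nitrogen gives a 1.1-fold lower number from compound 1 to compound 3 (0.05 log units; within the scatter), so these two side chains also cannot be told apart here. No supporting evidence is available that bears on this result.

The compounds shown leave open whether a phenyl group at this carbon would move the number beyond the scatter. The same question stands for an amine in place of the carboxylic acid.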